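The compounds below may be only part of what the source reports. "The series", "measured", "known", "first", "only" and "open" are said of these compounds alone.

Measured so far:
compound 1, `Cc1cc(Br)c(S(C)(=O)=O)cc1C(=O)N=C(N)N`: 12 nM
compound 2, `Cc1cc(C#N)c(S(C)(=O)=O)cc1C(=O)N=C(N)N`: 70 nM

In a functional assay for inhibition of sodium/hydrogen exchanger (Oryctolagus cuniculus) (a higher number here means a weaker inhibitor, a lower number a stronger inhibitor), compound 2 holds the higher of the two numbers. Within the data shown here, the only step measured at this carbon is a 5.8-fold higher number from compound 1 to compound 2 (0.77 log units; beyond the scatter), a modest one. Compound 3, `Cc1cc(-n2ccc(=O)cc2)c(S(C)(=O)=O)cc1C(=O)N=C(N)N`, is not yet measured; it differs from compound 2 by a group of 7 heavy atoms (5 carbon, 1 nitrogen, 1 oxygen; one six-membered aromatic ring with 1 hetero atom) in place of a group of 2 heavy atoms (1 carbon, 1 nitrogen; no ring), on an aromatic carbon, the site ortho to a methylsulfonyl group. Among the measured compounds shown here, no measured step places a ring on this carbon, so the bearing of the bromo-to-cyano step is indirect. A step of a 1.8-fold lower number from compound 2 to compound 3 (0.24 log units; within the scatter) is expected, without confidence in its direction. Compound 3 is estimated at 40 nM, range 8 nM to 200 nM.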

Compound 3, half-maximal inhibitory concentration: 75 nM
The estimate for compound 3 lay 1.9-fold (0.27 log units) below the measured number; the measured number falls inside the stated range.
By their numbers in this assay, from the lowest: compound 1; then compounds 2 and 3 (each within the scatter of the next).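

This carbon accepts a ring without a separable shift from the nitrile: in this assay, the group of 7 heavy atoms in place of cyano gives a 1.1-fold higher number from compound 2 to compound 3 (0.03 log units; within the scatter). In place of bromine, the same group gives a 6.3-fold higher number from compound 1 to compound 3 (0.80 log units; beyond the scatter), so compound 1 keeps the lowest number of the three. No available evidence explains either step.

Still open, on these data alone, is how an amine, a carboxylic acid or a saturated ring such as morpholine on this carbon would compare with bromine. Whether chlorine would match bromine is also unresolved.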